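A shared core, one swapped ring, three values and a guess

A few compounds are considered here, and "the series" means these few. Any claim that something is new, unique, unknown or untested is made for them only; others in the source may bear on it.

Compound 1 `C#CCSc1nc(Nc2ccc(F)cc2)c2ccncc2n1` is the reference point. Among the measured compounds shown here, in a functional assay on MGC-803 cells (Homo sapiens) for inhibition, read by MTT assay, with a stated time of 72 h (on this read-out higher numbers stand for weaker inhibition and lower numbers for stronger inhibition), compound 1 gives 15800 nM, the only plain number among the three values shown. Compound 2 `C#CCSc1nc(Nc2ccc([N+](=O)[O-])cc2)c2ccncc2n1` reaches only a limit of the assay, > 80000 nM. Compound 3 `C#CCSc1nc(Nc2ccc(OC)cc2)c2ccncc2n1` likewise stops at a limit, > 80000 nM. The two measured changes from compound 1 both weakened inhibition: an at least 5.0-fold higher number from compound 1 to compound 2 (0.70 log units; beyond the scatter), and an at least 5.0-fold higher number from compound 1 to compound 3 (0.70 log units; beyond the scatter). Between compound 2 and compound 3 the step stays unreadable, since both values sit at the limit of > 80000 nM in this assay, at which 2 of the 3 values shown sit.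

Compound 4 `C#CCSc1nc(Nc2ccccc2O)c2ccncc2n1` differs from compound 1 in one place: 2-hydroxyphenyl in place of 4-fluorophenyl on a nitrogen on an aromatic ring. For the measured compounds named here, no measured step swaps the whole ring this way, but the two steps that do replace the fluoro each pushed the number up by at least a modest amount, so a weakening is the more likely outcome here too. Compound 4 is therefore expected to show a step of about a 3.2-fold higher number from compound 1 to compound 4 (0.50 log units; beyond the scatter). For compound 4 the estimated value is 50000 nM, within a range from 12000 nM to 200000 nM.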

Compound 4, half-maximal inhibitory concentration: 21000 nM
Estimate against measurement, compound 4: 2.4-fold (0.38 log units) above; the range from low to high includes it.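

In this assay, replacing 4-fluorophenyl with 2-hydroxyphenyl gives a 1.3-fold higher number from compound 1 to compound 4 (0.12 log units; within the scatter), so compound 1 and compound 4 cannot be told apart. Among the compounds shown here, this is the first sign that the group on this nitrogen can change without a clear loss of inhibition, and compound 4 goes against the weakening seen in the two earlier changes. The entering group also carries a hydrogen-bond donor and acceptor, and compound 4 still gives a plain number rather than stopping at a limit: the limit of > 80000 nM in this assay, at which 2 of the 4 values shown sit.

The swap changes both the group and its place in the name, so the compounds shown cannot separate those two effects. On these data alone, how an amine or a carboxylic acid in place of the hydroxy group would read out also remains open.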